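Replacing an Amino Group on a Ring Nitrogen

This account rests on a few compounds, and the source may have more. Where it says the series, first, only, none or still open, it means among the compounds named here.

The measured compounds:
compound 1, `NN1C(=O)C(c2ccccc2)CC(c2ccccc2)C1=O`, 76%
compound 2, `O=C1C(c2ccccc2)CC(c2ccccc2)C(=O)N1c1cccc(Cl)c1`, 32.2%
compound 3, `NN1C(=O)C(c2ccccc2Cl)CC(c2ccccc2Cl)C1=O`, 73.3%

In a functional assay on the whole organism (strain Swiss albino) for inhibition, with Mus musculus as the target, in the maximal electroshock model, with a stated time of 2 h, at a dose of 25 mg/kg by the intraperitoneal route (on this read-out lower numbers stand for less inhibition and higher numbers for more inhibition at the one dose given (going by the name of the read-out)), compound 1 gives 76%. Compound 2 differs from it by one change, (3-chlorophenyl in place of amino on an amide-type nitrogen in a ring), and in this assay compound 2 gives 32.2%, a step of a number 43.8 percentage points lower from compound 1 to compound 2 (beyond the scatter). Compound 3 carries a different core, and in this assay compound 3 gives 73.3%, which lies within the scatter of the number for compound 1. The difference between the core of compound 3 and the core of compound 1 is not broken down here.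

Compound 4, `O=C1C(c2ccccc2Cl)CC(c2ccccc2Cl)C(=O)N1c1cccc(Cl)c1`, is not yet measured in this assay. It differs from compound 3 by 3-chlorophenyl in place of amino on an amide-type nitrogen in a ring. This is the same kind of change as that from compound 1 to compound 2: in the earlier pair the two ring atoms each bear a phenyl group, here they each bear a 2-chlorophenyl group, so the surroundings of the place are not identical. For the measured compounds named here, since compound 3 sits close to compound 1 in this assay, and the single prior example of this change gave the step of a number 43.8 percentage points lower from compound 1 to compound 2 (beyond the scatter), a step of roughly that size is expected for a number 43.3 percentage points lower from compound 3 to compound 4 (beyond the scatter). Compound 4 is therefore estimated at 30%, with a range from 12% to 50%, the width reflecting that this change has been seen only once and on a different core.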

Compound 4, a percentage reported as inhibition, in the whole organism at one dose (the size of the read-out at that dose, not a potency): 43.7%
For compound 4 the middle estimate is 13.7 percentage points below the measured one; measured number inside the range.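

Putting 3-chlorophenyl in place of amino on the amide-type nitrogen in the ring gives, in this assay, a number 29.6 percentage points lower from compound 3 to compound 4 (beyond the scatter), so the number falls on both cores and the direction of the change carries over. For the compounds shown here, the size of the step does not carry over unchanged, and the two steps differ: the same change on two cores in this assay, a number 43.8 percentage points lower (beyond the scatter) from compound 1 to compound 2 and a number 29.6 percentage points lower (beyond the scatter) from compound 3 to compound 4, 14.2 percentage points apart, beyond the scatter of two such steps With only two cores in hand, this shows that the drop recurred where two ring atoms each bear a phenyl group and where they each bear a 2-chlorophenyl group, but it does not show that the step has a fixed size, what sets the gap between the two steps, or whether the fall comes from losing amino or from gaining 3-chlorophenyl.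

The compounds shown leave open how other groups on the ring nitrogen, such as a methyl group, a benzyl group or an unsubstituted phenyl, would compare with amino and with 3-chlorophenyl on either core. Also open, on these data alone, is how the same change behaves when the two ring atoms each bear a different group, such as a 4-methoxyphenyl, and whether the step would hold at other doses or times.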